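From compound 1 to compound 4: a change on sulfur

The source may report more compounds than this note shows. Statements on the series, on what has been measured and on what is new or still open speak of the compounds shown alone.

compound 1 `Nc1ccccc1NC(=O)/C=C/c1ccc(CSc2ccc(Cl)cc2)cc1` 5.62%
compound 2 `Cc1ccc(SCc2ccc(C(=O)Nc3ccccc3N)cc2)cc1` 74.8%
compound 3 `Nc1ccccc1NC(=O)c1ccc(CSc2ccc(C(F)(F)F)cn2)cc1` 1.2%

In a functional assay on HCT-116 cells (Homo sapiens) for inhibition, read by CCK-8 assay, with a stated time of 72 h, tested at 2 uM (on this read-out higher numbers stand for more inhibition of growth at the one concentration tested and lower numbers for less inhibition of growth), compound 1 stands within the scatter of compound 3, while compound 2 lies far beyond the scatter above both of them. Compound 1 therefore belongs to the low pair of this small set.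

Compound 4 `Nc1ccccc1NC(=O)/C=C/c1ccc(CSCCc2ccccc2)cc1` has not yet been measured. It differs from compound 1 in one place, with phenethyl in place of 4-chlorophenyl on a sulfur.

Within the data shown here, no two measured compounds differ in only one place, so the data give no direct measure of what such a change does. The expectation therefore starts from compound 1 at 5.62% as its anchor. Compound 2 at 74.8% shows that a high value does occur among these compounds, and this widens the upper end of the range. The expected change in this assay is a number 6.4 percentage points higher from compound 1 to compound 4 (within the scatter) and so no step beyond the scatter, with no firm direction. The estimated value for compound 4 is 12% (expected range 0% to 40%).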

Compound 4, percent growth inhibition at one concentration: 18%
Estimate against measurement, compound 4: 6 percentage points below; the measured number falls inside the stated range.
By their numbers in this assay, from the lowest: compounds 3 and 1 (each within the scatter of the next); then compound 4; then compound 2.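

Among these compounds, the step gives the first direct reading of a change at this position: in this assay, phenethyl in place of 4-chlorophenyl on a sulfur gives a number 12.4 percentage points higher from compound 1 to compound 4 (beyond the scatter), a modest rise on the core of compound 1. It shows that this sulfur can carry phenethyl, a group without chlorine, and that the read-out then moves upward, although this rests on one pair of compounds. Nothing available here accounts for the rise, and the reason for it remains unknown.

Among the compounds shown here, this single pair cannot separate the loss of the chlorine from the arrival of the phenethyl chain, as both change together in the one exchange, so it remains open which of the two carries the step. The compounds shown also leave open how the read-out would respond to a plain phenyl or benzyl group on this sulfur, to a longer chain, or to an amine or a carboxylic acid at the end of the chain, and whether phenethyl would give a similar step on the core of compound 2.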